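Dichlorophenyl chalcone on the pyridyl ether core

The source may hold more compounds than are shown below. What is called first, only, known or untested is meant among the compounds shown, and "the series" means these compounds.

Compound 3 `CNC(=O)c1cc(Oc2ccc(C(=O)/C=C/c3ccccc3)cc2)ccn1` carries a plain phenyl on the chain and, in a functional assay on A549 cells (Homo sapiens) for cytotoxicity, read by MTT assay, with a stated time of 72 h (on this read-out higher numbers stand for weaker inhibition and lower numbers for stronger inhibition), compound 3 gives 5040 nM. Among the three measured analogues this is the lowest number, though the gaps to the other two do not clear the scatter: compound 1 `CNC(=O)c1cc(Oc2ccc(C(=O)/C=C/c3ccc(Cl)cc3Cl)cc2)ccn1` gives 9460 nM and compound 2 `CNC(=O)c1cc(Oc2ccc(C(=O)/C=C/c3cccc(Br)c3)cc2)ccn1` gives 9940 nM, and a 1.9-fold lower number from compound 1 to compound 3 (0.27 log units; within the scatter) while a 2.0-fold lower number from compound 2 to compound 3 (0.29 log units; within the scatter). Between the two halogenated analogues, a 1.1-fold higher number from compound 1 to compound 2 (0.02 log units; within the scatter).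

Compound 4 `CNC(=O)c1cc(Oc2ccc(C(=O)/C=C/c3ccc(Cl)c(Cl)c3)cc2)ccn1` is not yet measured. Its change from compound 3 is 3,4-dichlorophenyl in place of phenyl on a double-bonded chain carbon bound to a double-bonded chain carbon. Among the compounds with values here, the steps that bear on it are the phenyl-to-halophenyl comparisons already in hand, namely a 1.9-fold lower number from compound 1 to compound 3 (0.27 log units; within the scatter) and a 2.0-fold lower number from compound 2 to compound 3 (0.29 log units; within the scatter), each read in reverse for the present step; both put a halogenated ring at a slightly higher number than the bare phenyl, but neither step exceeds the scatter. By analogy, the expected step is a modest rise, a 1.6-fold higher number from compound 3 to compound 4 (0.20 log units; within the scatter), and it may well be no step beyond the scatter at all. For compound 4 the estimate in this assay is 8000 nM, with a range from 3500 nM to 20000 nM.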

Compound 4, half-maximal inhibitory concentration: 33700 nM
Estimate against measurement, compound 4: 4.2-fold (0.62 log units) below; measured number outside the range, above it.
By their numbers in this assay, from the lowest: compounds 3, 1 and 2 (each within the scatter of the next); then compound 4.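

In this assay, within the data shown here, the steps among compounds 1, 2 and 3 all stayed within the scatter, and the 3,4-dichlorophenyl on this double-bonded chain carbon is the first group in the set to break from them (a 6.7-fold higher number from compound 3 to compound 4 (0.83 log units; beyond the scatter)). Halogen on the ring does not by itself produce this rise, since the 3-bromophenyl of compound 2 and the 2,4-dichlorophenyl of compound 1 both remain within the scatter of the plain phenyl, while compound 4 stands clear of each (a 3.4-fold higher number from compound 2 to compound 4 (0.53 log units; beyond the scatter); a 3.6-fold higher number from compound 1 to compound 4 (0.55 log units; beyond the scatter)); the last of these steps keeps the same two chlorines on the ring and changes only their placement, so at this position the substitution pattern counts as well as the atoms present. Nothing at hand accounts for the rise.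

Still open, going by these compounds, is whether 3-chlorophenyl or 4-chlorophenyl on the same chain carbon would stay with compounds 1, 2 and 3 or move towards compound 4, and whether 3,4-difluorophenyl or 3,4-dimethoxyphenyl would follow the 3,4-dichlorophenyl. All four compounds also share the rest of the structure, so they cannot show whether this rise would persist with a carboxylic acid in place of the methyl amide.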